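A few compounds are considered here, and "the series" means these few. Any claim that something is new, unique, unknown or untested is made for them only; others in the source may bear on it.

Compound 1 `FC(F)(F)c1cccc(NC(=S)Nc2cccc(Br)c2)c1`: 10000 nM in an ADME assay on MDBK cells (Bos taurus) for cytotoxicity, read by MTT assay, with a stated time of 96 h; a higher number here means that more compound is tolerated, a lower number that less compound is tolerated
Compound 2 `COc1cccc(NC(=S)Nc2cccc(C(F)(F)F)c2)c1`: 52000 nM
Compound 3 `CCCCc1ccc(NC(=S)Nc2cccc(C(F)(F)F)c2)c(C)c1`: 10000 nM

Among these three, compound 1 sits together with compound 3 at the lowest number, the two not separable within the scatter, while compound 2 stands furthest from it; the only single-point step, a 5.2-fold higher number from compound 1 to compound 2 (0.72 log units; beyond the scatter), is a modest rise. The new compound 4 `FC(F)(F)c1cccc(NC(=S)NCc2ccco2)c1` differs from compound 1 in one place: (furan-2-yl)methyl in place of 3-bromophenyl on an amide-type nitrogen. Among the measured compounds shown here, this swaps one ring for another of a different size and kind rather than exchanging a substituent, so no measured step is a close match; the step from compound 1 to compound 2 shows only that a change on one ring can move the number modestly upward. A change of similar size, in either direction, seems the most likely outcome, so compound 4 is expected at 18000 nM, with a range from 6000 nM to 55000 nM, meaning an estimated step of a 1.8-fold higher number from compound 1 to compound 4 (0.26 log units; within the scatter).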

Compound 4, half-maximal cytotoxic concentration: > 100000 nM
Compound 4 was reported as a limit; the forecaster's own chance of this, stated with the estimate: 10%; at least 5.5-fold (0.74 log units) between middle value and limit.
By their numbers in this assay, from the lowest: compounds 1 and 3 (each within the scatter of the next); then compound 2. At a limit, above all of these: compound 4.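

In this assay, placing (furan-2-yl)methyl instead of 3-bromophenyl on the amide-type nitrogen gives an at least 10-fold higher number from compound 1 to compound 4 (1.00 log units; beyond the scatter). So replacing a whole aryl group at this nitrogen can also raise the number, whereas the earlier step showed only a substituent change on an aromatic carbon. The value for compound 4 is a limit, not a number: the limit of > 100000 nM in this assay, at which 1 of the 4 values shown sits.

The furan ring and its methyl link enter together, so the compounds shown do not separate their contributions. Benzyl on this nitrogen, or a furan-2-yl group attached directly, would pull those two parts apart.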